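Bromopyridinyl replaces pyridinyl on the acrylamide arm

A few compounds are considered here, and "the series" means these few. Any claim that something is new, unique, unknown or untested is made for them only; others in the source may bear on it.

Compound 1, `Clc1cccc(Nc2ncnc3ccc(NCc4cccc(Br)n4)cc23)c1`: 3870 nM
Compound 2, `Clc1cccc(Nc2ncnc3ccc(NCc4ccc(Br)s4)cc23)c1`: 3110 nM
Compound 3, `O=C(/C=C/c1cccnc1)Nc1ccc2ncnc(Nc3cccc(Cl)c3)c2c1`: 9120 nM

The three measured compounds share one core and differ in the arm on its aminated ring; all were tested in a functional assay on HepG2 cells (Homo sapiens) for antiproliferative activity, read by MTT assay, with a stated time of 48 h; a lower number here means a stronger inhibitor, a higher number a weaker inhibitor. Compound 3, with its acrylamide arm carrying pyridin-3-yl, gives the highest of the three numbers, and both gaps to the other two compounds lie beyond the scatter, so on these numbers compound 3 is the weakest. Compound 4, `O=C(/C=C/c1cccc(Br)n1)Nc1ccc2ncnc(Nc3cccc(Cl)c3)c2c1`, keeps the acrylamide arm of compound 3 and differs from it in one place: 6-bromopyridin-2-yl in place of pyridin-3-yl on a double-bonded chain carbon bound to a double-bonded chain carbon.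

Among the compounds with values here, no measured pair swaps pyridin-3-yl for 6-bromopyridin-2-yl. Within the data shown here, the only step that touches a related group is a 1.2-fold lower number from compound 1 to compound 2 (0.09 log units; within the scatter), where 6-bromopyridin-2-yl is exchanged for 5-bromothiophen-2-yl on a saturated chain carbon; that step stayed within the scatter. Whether the bromopyridinyl group on the double-bonded chain of compound 4 behaves like that is not shown by any measured step, so the expected step is one of no change beyond the scatter, with a wide range around it.

Compound 4 is therefore expected to give about 7000 nM in this assay, with a range from 2500 nM to 20000 nM. The step from compound 3 to compound 4 is estimated at a 1.3-fold lower number from compound 3 to compound 4 (0.11 log units; within the scatter).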

Compound 4, half-maximal inhibitory concentration: 10700 nM
Estimate against measurement, compound 4: 1.5-fold (0.18 log units) below, and the stated range covers the measured number.
By their numbers in this assay, from the lowest: compounds 2 and 1 (each within the scatter of the next); then compounds 3 and 4 (each within the scatter of the next).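

In this assay, the change of the ring group on the acrylamide arm gives a 1.2-fold higher number from compound 3 to compound 4 (0.07 log units; within the scatter) and so leaves the number within the scatter. Within the data shown here, this is the first reading at this place on the acrylamide arm: the earlier compounds offered no pair that varied the group there, and the exchange, which brings in a bromine atom and a different point of attachment on the ring, does not separate compound 3 from compound 4 in this assay. Nothing available here offers an explanation for this result.

Compound 4 differs from compound 3 in both the bromine atom and the point of attachment, so the compounds shown leave open what each of these contributes alone, as plain pyridin-2-yl or 5-bromopyridin-3-yl on the same arm would show. They also leave open whether an amine or a carboxylic acid on this ring, or a longer chain between the ring and the amide carbonyl, would shift the number beyond the scatter.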